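A few compounds are considered here, and "the series" means these few. Any claim that something is new, unique, unknown or untested is made for them only; others in the source may bear on it.

Among the compounds with values here, compound 2 `Cc1ccc(-c2nc(CNc3ccc(C(=O)NO)cc3)n(-c3ccccc3)n2)s1` holds the lowest number of the two measured so far in an assay on Sf9 cells for inhibition of protein deacetylase HDAC6 (Homo sapiens), read by fluorescence, with a stated time of 40 min (on this read-out higher numbers stand for weaker inhibition and lower numbers for stronger inhibition), at 30.6 nM; its nearest neighbour is compound 1 `O=C(NO)c1ccc(NCc2nc(-c3ccc(F)cc3)nn2-c2ccccc2)cc1`, which in this assay gives 115 nM. Within the data shown here, the only measured step, a 3.8-fold lower number from compound 1 to compound 2 (0.57 log units; beyond the scatter), is the swap of one aromatic group for another on the same carbon of the shared core. Compound 3 `O=C(NO)c1ccc(NCc2nc(-c3ccccc3)nn2-c2ccccc2)cc1` takes that carbon one move further: phenyl in place of 5-methylthiophen-2-yl on an aromatic carbon. Among the measured compounds shown here, no measured step pairs a phenyl with the 5-methylthiophen-2-yl, so the bearing of the existing step is indirect; it shows that a change of the aryl group at this position can shift the number modestly. Compound 3 is expected to move back toward compound 1, with an estimated 2.9-fold higher number from compound 2 to compound 3 (0.47 log units; beyond the scatter), so compound 3 is expected to give about 90 nM, within a range of 35 nM to 230 nM.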

Compound 3, half-maximal inhibitory concentration: 112 nM
The estimate for compound 3 lay 1.2-fold (0.09 log units) below the measured number, and the stated range covers the measured number.
By their numbers in this assay, from the lowest: compound 2; then compounds 3 and 1 (each within the scatter of the next).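

In this assay, the direct swap at this carbon gives a 3.7-fold higher number from compound 2 to compound 3 (0.56 log units; beyond the scatter), so phenyl and 5-methylthiophen-2-yl can now be compared without going through a third group. The fluoro on the phenyl makes no difference that can be read here: hydrogen in its place gives a 1.0-fold lower number from compound 1 to compound 3 (0.01 log units; within the scatter), so among the three compounds only the 5-methylthiophen-2-yl stands apart from the others. No measured evidence bears on why this group gives the lower number.

The compounds shown leave open whether that lower number belongs to the sulfur-containing ring or to its methyl group, a question that an unsubstituted thiophen-2-yl would address. They also leave open how a furan-2-yl, a pyridyl group or an amine on the phenyl would read at this carbon.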